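A smaller group on a four-membered ring

The source may hold more compounds than are shown below. What is called first, only, known or untested is meant among the compounds shown, and "the series" means these compounds.

- Compound 1 `COc1nnc2ccc(N3CCC(c4ccc(OCCCCN5CCN(C)C(=O)[C@H]5C)cc4)CC3)nn12` gives 470000 nM as a number
- Compound 2 `COc1nnc2ccc(N3CCC(c4ccc(N5CC(CN6CCN(C)C(=O)[C@H]6C)C5)cc4)CC3)nn12` gives > 460000 nM as a limit

Both results come from a physicochemical assay for solubility, measured as thermodynamic solubility, at pH 7.4 (on this read-out higher numbers stand for higher solubility and lower numbers for lower solubility), and are the only data so far. Compound 2 stands at a limit of the assay, shown as > 460000 nM here, and not at a number. In short, the evidence is the limit of > 460000 nM in this assay, at which 1 of the 2 values shown sits, and no more.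

Compound 3 `COc1nnc2ccc(N3CCC(c4ccc(N5CC(N6CCN(C)C(=O)[C@H]6C)C5)cc4)CC3)nn12` keeps the rest of compound 2 and changes one place: a group of 9 heavy atoms (6 carbon, 2 nitrogen, 1 oxygen; one six-membered non-aromatic ring with 2 hetero atoms) in place of a group of 10 heavy atoms (7 carbon, 2 nitrogen, 1 oxygen; one six-membered non-aromatic ring with 2 hetero atoms), on a saturated ring carbon is the counted difference.

Going by the values given here, no measured pair shows what such a swap does in this assay on its own, so no step beyond the usual scatter is expected. Compound 1, with 470000 nM as a true number, supports an expectation in the same region. The expected change is a number no higher from compound 2 to compound 3 (the limit leaves the size open) as estimated here. For compound 3 the expected value is 460000 nM with an estimated range from 300000 nM to 520000 nM in this read-out.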

Compound 3, solubility: 870000 nM
For compound 3 the middle estimate is 1.9-fold (0.28 log units) below the measured one, outside the stated range (above it).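

The size of the change from compound 2 to compound 3 cannot be read, since compound 2 stands at a limit and not at a number: the limit of > 460000 nM in this assay, at which 1 of the 3 values shown sits.

The compounds shown leave open what putting the group of 9 heavy atoms in place of the group of 10 heavy atoms does on its own in this assay.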